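The source may hold more compounds than are shown below. What is called first, only, known or untested is meant among the compounds shown, and "the series" means these compounds.

Going by the values given here, compound 2 `O=C(O)c1ccc(S(=O)(=O)N2CCC(NS(=O)(=O)c3cc(S(=O)(=O)c4ccccc4)ccc3C(F)(F)F)CC2)cc1` gives the lower of the two numbers so far recorded in an assay on isolated protein for displacement of a labelled ligand from secreted frizzled-related protein 1 (Homo sapiens), read by fluorescence polarization, with a stated time of 30 min; a lower number here means a stronger inhibitor, a higher number a weaker inhibitor: compound 2 gives 20 nM, while compound 1 `O=C(c1ccc(Cl)nc1)N1CCC(NS(=O)(=O)c2cc(S(=O)(=O)c3ccccc3)ccc2C(F)(F)F)CC1` gives 110 nM. Among the compounds with values here, the only measured step, a 5.5-fold lower number from compound 1 to compound 2 (0.74 log units; beyond the scatter), shows that the acid-bearing sulfonyl aryl group on the ring nitrogen is worth a modest gain over the chloropyridinyl carbonyl group in that position. Compound 3 `CC(C)(O)CCN1CCC(NS(=O)(=O)c2cc(S(=O)(=O)c3ccccc3)ccc2C(F)(F)F)CC1` takes a different direction at the same ring nitrogen: 3-hydroxy-3-methylbutyl in place of (4-carboxyphenyl)sulfonyl on an amine nitrogen in a ring. Within the data shown here, no measured pair shows what a short hydroxyalkyl chain does in place of an aromatic group there, so the expectation rests on the one step and on the size of what is removed. Since the step to compound 2 gained from the larger aryl acid, its loss is expected to cost potency, estimated as a 15-fold higher number from compound 2 to compound 3 (1.18 log units; beyond the scatter) for compound 3. Compound 3 is therefore expected to give 300 nM in this assay, within a range from 70 nM to 1300 nM.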

Compound 3, half-maximal inhibitory concentration: 200 nM
Compound 3: middle estimate off by 1.5-fold (0.18 log units), on the high side; the range from low to high includes it.
By their numbers in this assay, from the lowest: compound 2; then compounds 1 and 3 (each within the scatter of the next).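

In this assay, replacing the aryl acid with an open chain that has no ring gives a 10-fold higher number from compound 2 to compound 3 (1.00 log units; beyond the scatter), so compound 2 keeps a clear lead over both other groups tried on this ring nitrogen. The other new step, a 1.8-fold higher number from compound 1 to compound 3 (0.26 log units; within the scatter), leaves 3-hydroxy-3-methylbutyl and (6-chloropyridin-3-yl)carbonyl indistinguishable, which shows that among these three compounds an aromatic ring on this nitrogen does not by itself separate the numbers. Nothing given here explains these differences.

The compounds shown leave open whether the gain in compound 2 belongs to the carboxylic acid, to the sulfonyl link or to the two together. A plain phenylsulfonyl group and a 4-carboxybenzoyl group on this nitrogen would each change only one of those features.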